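The compounds below may be only part of what the source reports. "The series", "measured", "known", "first", "only" and "open" are said of these compounds alone.

Series notes on the shared core. Compound 3 `O=C(c1ccccc1F)N1CC(c2nc(-c3cccc(Cl)c3)no2)C1` stands at the edge of what an assay on HEK293 cells for positive allosteric modulation of metabotropic glutamate receptor 5 (Homo sapiens), read by FLIPR (on this read-out lower numbers stand for an effect already at smaller amounts and higher numbers for an effect only at larger amounts of compound), reports: in this assay compound 3 gives > 10000 nM, which is a limit rather than a number. Compound 1 `O=C(C1CCCO1)N1CC(c2nc(-c3cccc(Cl)c3)no2)C1` likewise gives a limit in this assay, > 10000 nM, as described in the limit of > 10000 nM in this assay, at which 2 of the 3 values shown sit. Compound 2 `O=C(N1CCCCCC1)N1CC(c2nc(-c3cccc(Cl)c3)no2)C1` gives 47 nM in this assay. Compound 4 `O=C([C@@H]1CC2CCC1C2)N1CC(c2nc(-c3cccc(Cl)c3)no2)C1` differs from compound 3 by a group of 7 heavy atoms (7 carbon; 2 five-membered non-aromatic rings of carbon only) in place of a group of 7 heavy atoms (6 carbon, 1 fluorine; one six-membered aromatic ring of carbon only), on a carbonyl carbon. Going by the values given here, the steps that bear on this change are an at least 210-fold higher number from compound 2 to compound 3 (2.32 log units; beyond the scatter) and an at least 210-fold lower number from compound 1 to compound 2 (2.32 log units; beyond the scatter), both large, while a step that the two limits leave unreadable from compound 1 to compound 3. The entering group shares the non-aromatic character of azepan-1-yl but, like oxolan-2-yl, is joined through carbon, so the expected step is an at least 6.6-fold lower number from compound 3 to compound 4 (0.82 log units; beyond the scatter), with a wide range. For compound 4 the estimate in this assay is 1500 nM, between 150 nM and 10000 nM.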

Compound 4, half-maximal effective concentration: 98 nM
Beside the measured number, compound 4's estimate is 15-fold (1.18 log units) above it, outside the stated range (below it).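

Going by these compounds alone, at this place on a carbonyl carbon, the earlier compounds left it unclear whether a group joined through carbon could give a low number, and compound 4 shows that one can, with an at least 100-fold lower number from compound 3 to compound 4 (2.00 log units; beyond the scatter) and an at least 100-fold lower number from compound 1 to compound 4 (2.00 log units; beyond the scatter). Azepan-1-yl is thus not the only group that serves here, although a modest gap remains, with a 2.1-fold higher number from compound 2 to compound 4 (0.32 log units; beyond the scatter). Compounds 1 and 3 stay at a limit: the limit of > 10000 nM in this assay, at which 2 of the 4 values shown sit.

Compound 4 differs from compound 2 in both ring and joining atom, so the share of each stays unresolved. Also open, from the compounds shown here alone, is whether cyclohexyl or piperidin-1-yl on this carbonyl carbon would keep the number low.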